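The source may report more compounds than this note shows. Statements on the series, on what has been measured and on what is new or still open speak of the compounds shown alone.

In a functional assay on B16 cells (Mus musculus) for cytotoxicity, read by MTT assay, with a stated time of 48 h (on this read-out lower numbers stand for stronger inhibition and higher numbers for weaker inhibition), compound 1 `C#CC1=CC[C@@]2(C)C(=C)CCC[C@]2(C)CC1` gives 507000 nM and compound 2 `C=C1CCC[C@]2(C)CCC(c3cn(-c4ccc(OC)cc4)nn3)=CC[C@@]12C` gives 209000 nM, the lower of the two numbers, with a gap beyond the usual scatter. Compound 3 `C=C1CCC[C@]2(C)CCC(c3cn(-c4ccc(C(C)=O)cc4)nn3)=CC[C@@]12C` has not yet been measured. It carries acetyl in place of methoxy on an aromatic carbon, para to a large group (acetyl in place of methoxy on an aromatic carbon). Among the measured compounds shown here, no measured pair shows this change, so in this assay a shift within the scatter is expected, with no direction favoured. The expected step is a 1.0-fold lower number from compound 2 to compound 3 (0.02 log units; within the scatter). For compound 3 the estimated value is 200000 nM, with a range of 90000 nM to 420000 nM.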

Compound 3, half-maximal inhibitory concentration: 61000 nM
For compound 3 the middle estimate is 3.3-fold (0.52 log units) above the measured one, and the stated range ends above it.
By their numbers in this assay, from the lowest: compound 3; then compound 2; then compound 1.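

Acetyl in place of methoxy on an aromatic carbon, para to a large group, comes with a 3.4-fold lower number from compound 2 to compound 3 (0.53 log units; beyond the scatter) in this assay. Among the compounds shown here, the earlier compounds offered no pair differing in one place, so this is the first sign that the group at this position moves the read-out, with 4-acetylphenyl giving the lower number of the two. Nothing measured here accounts for the shift. From the compounds shown here alone, whether a nitrile, a carboxylic acid or an amine at this same position would lower the number further remains open.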